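Swapping the Aryl Group on the Sulfonyl Sulfur

A few compounds are considered here, and "the series" means these few. Any claim that something is new, unique, unknown or untested is made for them only; others in the source may bear on it.

Of the compounds shown here, three sharing one core have been tested in a functional assay on HCT-116 cells (Homo sapiens) for inhibition, read by MTT assay, with a stated time of 72 h; a lower number here means a stronger inhibitor, a higher number a weaker inhibitor. Compound 1 `CCOC(=O)c1oc2ccc(NS(=O)(=O)c3ccc(C(F)(F)F)cc3)cc2c1C` gives 5030 nM. Compound 2 `CCOC(=O)c1oc2ccc(NS(=O)(=O)c3ccc(Cl)cc3)cc2c1C` gives 24300 nM, and the step of a 4.8-fold higher number from compound 1 to compound 2 (0.68 log units; beyond the scatter) shows that a single substituent on an aromatic carbon can shift the result. Compound 3 `CCOC(=O)c1oc2ccc(N(Cc3ccccc3)S(=O)(=O)c3ccccc3Br)cc2c1C` reaches only the limit of this assay, > 40000 nM, so no exact number is known for it (the limit of > 40000 nM in this assay, at which 1 of the 3 values shown sits). Compound 4 `CCOC(=O)c1oc2ccc(N(Cc3ccccc3)S(=O)(=O)c3ccc([N+](=O)[O-])cc3)cc2c1C` differs from compound 3 by 4-nitrophenyl in place of 2-bromophenyl on a sulfonyl sulfur. Within the data shown here, only the step from compound 1 to compound 2 bears on this kind of change, and it was modest; since compound 3 sits at a limit, the expected step of a number no higher from compound 3 to compound 4 (the limit leaves the size open) cannot be anchored, and compound 4 is expected to stay weak in this assay. Compound 4 is estimated at 40000 nM, within 12000 nM to 100000 nM.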

Compound 4, half-maximal inhibitory concentration: > 40000 nM
Compound 4 was reported as a limit (the forecaster's own chance of this, stated with the estimate: 55%); the middle value lies on the limit itself.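

Among these compounds, compound 3 and compound 4 are both reported only as limits in this assay, so no step between them can be read. From the compounds shown here alone, how 4-nitrophenyl compares with 2-bromophenyl on a sulfonyl sulfur stays open.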